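The source may hold more compounds than are shown below. What is called first, only, known or untested is meant among the compounds shown, and "the series" means these compounds.

Measured compounds:
compound 1, `Fc1ccccc1C1Cc2nccn2C1`, with 1770 nM;
compound 2, `COc1ccccc1C1Cc2nccn2C1`, with "not determined" (no result reported).

Two compounds with a shared core have been examined in a functional assay on CHO cells for agonist activity at Alpha-1B adrenergic receptor (Homo sapiens), read by FLIPR and calcium flux; on this read-out higher numbers stand for an effect only at larger amounts of compound and lower numbers for an effect already at smaller amounts. Compound 1 gives 1770 nM in this assay. Compound 2 has no reported result in this assay, so there is no single number on which compound 2 can be placed; the only measured point among these compounds is compound 1.

Compound 3, `Clc1ccccc1C1Cc2nccn2C1`, has not yet been measured. It differs from compound 2 by chloro in place of methoxy on an aromatic carbon. Among the compounds with values here, as no step between measured compounds exists for this pair, and compound 2 itself carries no value, the size and direction of the step cannot be anchored; with compound 1 as the sole measured reference, the value of compound 3 is expected to lie near it, within the usual scatter. Compound 3 is estimated at 1500 nM, in the range 400 nM to 6000 nM.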

Compound 3, half-maximal effective concentration: 1100 nM
The estimate for compound 3 lay 1.4-fold (0.13 log units) above the measured number, and the stated range covers the measured number.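

In this assay, the aromatic carbon ortho to a group of 8 heavy atoms now has its first readable change, chloro in place of fluoro, which gives a 1.6-fold lower number from compound 1 to compound 3 (0.21 log units; within the scatter). At this position, then, the read-out does not separate chloro from fluoro, while the step from compound 2 to compound 3 cannot be read, since compound 2 has no result. No other measurement shown here bears on this result.

On these data alone, it remains open whether a group of a different kind at this position, such as an amine, a carboxylic acid or a longer chain, would stay within the scatter of these numbers or move beyond it. Also open, as far as these compounds go, are where methoxy would stand against chloro and fluoro and what a change elsewhere on the shared core would do.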